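Aryl variation on the benzylic carbon of the shared core

This account rests on a few compounds, and the source may have more. Where it says the series, first, only, none or still open, it means among the compounds named here.

Going by the values given here, compound 2 `O=C(O)c1ccccc1-c1ccc(CCc2ncc(Cc3ccccc3F)[nH]2)cc1` stands lowest of the two numbers so far: in an in vitro functional assay on cells for agonist activity at Bombesin receptor subtype-3 (Mus musculus), read by luminescence and calcium flux (a higher number here means that more compound is needed for the effect, a lower number that less compound is needed), compound 2 gives 9.5 nM, while compound 1 `COc1cccc(Cc2cnc(CCc3ccc(-c4ccccc4C(=O)O)cc3)[nH]2)c1` gives 79 nM in this assay. Among the compounds with values here, the one step measured, an 8.3-fold lower number from compound 1 to compound 2 (0.92 log units; beyond the scatter), shows that the aryl group on this saturated chain carbon shifts the read-out well beyond the scatter. Compound 3 `N#Cc1ccc(Cc2cnc(CCc3ccc(-c4ccccc4C(=O)O)cc3)[nH]2)cc1` carries the change (4-cyanophenyl in place of 2-fluorophenyl on a saturated chain carbon bound to an aromatic carbon). Within the data shown here, the only step that bears on it is an 8.3-fold lower number from compound 1 to compound 2 (0.92 log units; beyond the scatter); it tells that this position is sensitive, but nothing about 4-cyanophenyl itself, so the direction is open. Given that compound 2 is the lowest number and the one measured change here was large, a move upward from compound 2 by a modest amount is expected, a 4.2-fold higher number from compound 2 to compound 3 (0.62 log units; beyond the scatter). Compound 3 is estimated at 40 nM in this assay, within the range 8 nM to 200 nM.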

Compound 3, half-maximal effective concentration: 723 nM
For compound 3 the middle estimate is 18-fold (1.26 log units) below the measured one; measured number above the stated range.
By their numbers in this assay, from the lowest: compound 2; then compound 1; then compound 3.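

In this assay, going by these compounds alone, the aryl group on this saturated chain carbon now spans a much wider range than the first pair showed: 4-cyanophenyl in place of 2-fluorophenyl gives a 76-fold higher number from compound 2 to compound 3 (1.88 log units; beyond the scatter) and is the largest step so far. Against 3-methoxyphenyl, the same group gives a 9.2-fold higher number from compound 1 to compound 3 (0.96 log units; beyond the scatter) and places compound 3 highest of the three, so this aryl exchange can also raise the number sharply. No measurement available here explains the rise with 4-cyanophenyl.

2-Fluorophenyl and 4-cyanophenyl differ in both the group carried and its ring position, so these compounds cannot separate those two changes. 2-Cyanophenyl and 4-fluorophenyl would bear on that question, while an amine or a carboxylic acid on this aryl ring remains open.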